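Furan-2-yl replacement on the amine side of the series

The compounds below may be only part of what the source reports. "The series", "measured", "known", "first", "only" and "open" are said of these compounds alone.

Measured compounds:
compound 1 `COc1cccc(CNCCCNc2ccnc3cc(Cc4ccccc4)ccc23)c1O`, in an ADME assay on HepG2 cells (Homo sapiens) for cytotoxicity, read by luminescence, CellTiter-Glo and ATP content, with a stated time of 72 h (on this read-out lower numbers stand for an effect already at smaller amounts and higher numbers for an effect only at larger amounts of compound), compound 1 gives 5720 nM
compound 2 `COc1cccc(Oc2ccc3c(NCCCNCc4cccc(OC)c4O)ccnc3c2)c1`, compound 2 gives 5300 nM
compound 3 `COc1cccc(CNCCCNc2ccnc3cc(Cc4cccc(C(F)(F)F)c4)ccc23)c1O`, compound 3 gives 1720 nM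

Compound 1 has the highest number of the three; compound 2 lies nearest, a 1.1-fold lower number from compound 1 to compound 2 (0.03 log units; within the scatter), and compound 3 furthest, a 3.3-fold lower number from compound 1 to compound 3 (0.52 log units; beyond the scatter).

Compound 4 `c1ccc(Cc2ccc3c(NCCCNCc4ccco4)ccnc3c2)cc1` differs from compound 1 by furan-2-yl in place of 2-hydroxy-3-methoxyphenyl on a saturated chain carbon bound to an amine nitrogen.

Both measured steps concern the substituent on the core, not the group bound through the amine chain; neither bears on this change, and there is no measured case of any exchange at that place. Without a precedent, the expectation for compound 4 is no step beyond the scatter, a 1.1-fold lower number from compound 1 to compound 4 (0.06 log units; within the scatter). Compound 4 is therefore estimated at 5000 nM, with a range from 2000 nM to 12500 nM.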

Compound 4, half-maximal effective concentration: 16000 nM
Compound 4: the middle estimate sits 3.2-fold (0.51 log units) below what was measured; measured number outside the range, above it.
By their numbers in this assay, from the lowest: compound 3; then compounds 2 and 1 (each within the scatter of the next); then compound 4.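

In this assay, among the compounds shown here, the first exchange at the saturated chain carbon bound to an amine nitrogen is not silent: furan-2-yl in place of 2-hydroxy-3-methoxyphenyl gives a 2.8-fold higher number from compound 1 to compound 4 (0.45 log units; beyond the scatter), so this place also moves the number. The direction is opposite to that of the core substituent step (a 3.3-fold lower number from compound 1 to compound 3 (0.52 log units; beyond the scatter)). No measurement at hand accounts for this step.

Open, going by these compounds, is whether the smaller ring or the loss of the hydroxy and methoxy groups carries the step. On these data alone, whether 2-hydroxyphenyl or pyridin-2-yl at this place stays with compound 1 or moves with compound 4 also remains open.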